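From diethylcarbamoyl to 2-carboxyethenyl on a shared core

This account rests on a few compounds, and the source may have more. Where it says the series, first, only, none or still open, it means among the compounds named here.

In a functional assay (aorta) with Rattus norvegicus as the target (on this read-out higher numbers stand for an effect only at larger amounts of compound and lower numbers for an effect already at smaller amounts), compound 3 `CCN(CC)C(=O)c1nc(-c2ccc(OC)cc2)c(-c2ccc(OC)cc2)s1` gives 14 uM. This is level, within the scatter, with compound 1 `COc1ccc(-c2nc(/N=C(\N)[N+]3(C)CCCCC3)sc2-c2ccc(OC)cc2)cc1` at 21 uM, while compound 2 `COc1ccc(-c2nc(CNC(=O)CSC)sc2-c2ccc(OC)cc2)cc1` gives a lower 6 uM. Compound 4 `COc1ccc(-c2nc(/C=C/C(=O)O)sc2-c2ccc(OC)cc2)cc1` has 2-carboxyethenyl in place of diethylcarbamoyl on an aromatic carbon. Among the measured compounds shown here, no measured compound carries this new group, so the evidence is indirect. Other exchanges at the same place produced only small steps: a 3.5-fold lower number from compound 1 to compound 2 (0.54 log units; beyond the scatter), a 2.3-fold higher number from compound 2 to compound 3 (0.37 log units; beyond the scatter) and a 1.5-fold lower number from compound 1 to compound 3 (0.18 log units; within the scatter). Since these steps stay modest or smaller, no step beyond the scatter is expected in this assay. The estimated step is a 1.1-fold higher number from compound 3 to compound 4 (0.03 log units; within the scatter). Compound 4 is expected at 15 uM, within an estimated range of 5 uM to 45 uM.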

Compound 4, concentration for half-maximal effect: 55 uM
The estimate for compound 4 lay 3.7-fold (0.56 log units) below the measured number; measured number above the stated range.
By their numbers in this assay, from the lowest: compound 2; then compounds 3 and 1 (each within the scatter of the next); then compound 4.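

In this assay, among the compounds shown here, this position proves less forgiving than the earlier compounds suggested: placing 2-carboxyethenyl here brings a 3.9-fold higher number from compound 3 to compound 4 (0.59 log units; beyond the scatter). The gap widens to a 9.2-fold higher number from compound 2 to compound 4 (0.96 log units; beyond the scatter), and there is also a 2.6-fold higher number from compound 1 to compound 4 (0.42 log units; beyond the scatter), so compound 4 needs the largest amount of the four to show its effect.

No measurement shown explains this shift. On these data alone, whether the carboxylic acid or the double bond matters more stays open: a saturated 2-carboxyethyl group or a methyl ester at the same place would help separate the two.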